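The source may report more compounds than this note shows. Statements on the series, on what has been measured and on what is new or still open speak of the compounds shown alone.

Measured so far: compound 1 `Cc1c(CC(C)C)c(=O)on1C(=O)N1CCCCC1`, 5 nM; compound 2 `Cc1c(C(C)(C)C)c(=O)on1C(=O)N1CCCCC1`, 14 nM; compound 3 `Cc1c(C2CCSCC2)c(=O)on1C(=O)N1CCCCC1`, 11 nM.

In an assay (strain Wistar) for inhibition of Hormone-sensitive lipase (Rattus norvegicus), read by spectrophotometry (a lower number here means a stronger inhibitor, a higher number a weaker inhibitor), compound 1 holds the lowest number of the three: a 2.2-fold higher number from compound 1 to compound 3 (0.34 log units; beyond the scatter) and a 2.8-fold higher number from compound 1 to compound 2 (0.45 log units; beyond the scatter). Compound 4 `Cc1c(CC(C)C)c(=O)on1C(=O)N1CCC(c2ccccc2)CC1` differs from compound 1 by phenyl in place of hydrogen on a saturated ring carbon. For the measured compounds named here, none of the measured steps touches that saturated ring; a 1.3-fold lower number from compound 2 to compound 3 (0.10 log units; within the scatter) and the two steps from compound 1 all concern the group on the aromatic carbon, and each stays modest. The measured data therefore give no direct guide to the step from compound 1 to compound 4, and the expectation in this assay is a small step at most, with no firm direction. Compound 4 is estimated at 6 nM, range 2 nM to 20 nM, an expected step of a 1.2-fold higher number from compound 1 to compound 4 (0.08 log units; within the scatter).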

Compound 4, half-maximal inhibitory concentration: 10 nM
Beside the measured number, compound 4's estimate is 1.7-fold (0.22 log units) below it, and the stated range covers the measured number.
By their numbers in this assay, from the lowest: compounds 1, 4, 3 and 2 (each within the scatter of the next, the first and the last beyond it).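

Phenyl in place of hydrogen on a saturated ring carbon, three ring bonds from the ring nitrogen, gives in this assay a 2.0-fold higher number from compound 1 to compound 4 (0.30 log units; within the scatter) and so no shift beyond the scatter. The saturated ring therefore accepts this addition, which the earlier steps, all on the aromatic carbon, could not show. (No measured evidence bears on why).

Open, from the compounds shown here alone, is whether an amine or a carboxylic acid at this ring carbon would be accepted equally, and whether phenyl here behaves the same alongside tert-butyl or thian-4-yl on the aromatic carbon.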